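The compounds below may be only part of what the source reports. "The series", "measured", "known", "first", "only" and "open" are said of these compounds alone.

In a functional assay on KB cells (Homo sapiens) for antiproliferative activity, read by MTT assay, with a stated time of 72 h (a higher number here means a weaker inhibitor, a lower number a stronger inhibitor), compound 1 (`CCOC(=O)c1cc(-c2cc(OC)c(OC)c(OC)c2)c(-c2ccc3ccccc3c2)s1`) gives 5890 nM, and compound 2 (`COc1cc(-c2cc(C(=O)O)sc2-c2ccc3ccccc3c2)cc(OC)c1OC`) gives 5640 nM. Going by the values given here, these are the only two values so far, and they lie within the scatter of each other, so compound 2 stands level with compound 1. Compound 3 (`COc1cc(-c2ccsc2-c2ccc3ccccc3c2)cc(OC)c1OC`) differs from compound 2 by hydrogen in place of carboxy on an aromatic carbon, next to the ring sulfur: hydrogen in place of carboxy on an aromatic carbon.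

Among the compounds with values here, only one measured step bears on this change, a 1.0-fold lower number from compound 1 to compound 2 (0.02 log units; within the scatter). It altered the end of the group on that carbon, with hydrogen in place of ethyl on an oxygen next to a carbonyl group, and it left the number within the scatter. Within the data shown here, it says little about losing the whole group, and no measured compound yet lacks that group. A step beyond the scatter is therefore possible, and a lower number in this assay is tentatively expected, with wide uncertainty. The expected change is a 3.8-fold lower number from compound 2 to compound 3 (0.58 log units; beyond the scatter), an estimate only. For compound 3 the estimated value is 1500 nM. For compound 3 the expected range runs from 100 nM to 8000 nM.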

Compound 3, half-maximal inhibitory concentration: 3660 nM
For compound 3 the middle estimate is 2.4-fold (0.39 log units) below the measured one, and the stated range covers the measured number.
By their numbers in this assay, from the lowest: compounds 3, 2 and 1 (each within the scatter of the next).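

In this assay, the whole carboxy group can be replaced by hydrogen on this aromatic carbon next to the ring sulfur without a step beyond the scatter: a 1.5-fold lower number from compound 2 to compound 3 (0.19 log units; within the scatter). The earlier step changed only the end of the group, whereas this one removes it entirely, and the full replacement of ethoxycarbonyl by hydrogen also stays within the scatter: a 1.6-fold lower number from compound 1 to compound 3 (0.21 log units; within the scatter). Hydrogen, carboxy and ethoxycarbonyl at this position are therefore not separated by this measurement, and nothing available here explains that result.

The compounds shown leave open whether an amine, a primary amide or a methyl group on this carbon would give a step beyond the scatter, as all three values so far come from hydrogen or from the two carbonyl-bearing groups. They also leave open how the number would respond to a change elsewhere on the shared core, such as a phenyl group in place of the naphthalen-2-yl group, which all three compounds carry.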